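This account rests on a few compounds, and the source may have more. Where it says the series, first, only, none or still open, it means among the compounds named here.

In a functional assay on HOS-TE85 cells (Homo sapiens) for inhibition, read by CCK-8 assay, with a stated time of 72 h (a higher number here means a weaker inhibitor, a lower number a stronger inhibitor), the measured compounds stand as follows:
- compound 1 `COc1ccc(C)cc1N1C(=O)CSC1c1cccc(C(=O)NCCCCc2ccccc2)c1` gives 300 nM
- compound 2 `CC1SC(c2cccc(C(=O)NCCCCc3ccccc3)c2)N(c2ccc(C3CC3)cc2)C1=O` gives 191 nM
- compound 3 `COc1ccccc1N1C(=O)CSC1C(=O)NCCCCc1ccccc1` gives > 1000 nM as a limit, not a number

Compound 1 at 300 nM and compound 2 at 191 nM lie within the usual scatter of each other. Compound 4 `CCN(CC)c1ccc(N2C(=O)CSC2c2cccc(C(=O)NCCCCc3ccccc3)c2)cc1` has not yet been measured. It carries 4-(diethylamino)phenyl in place of 2-methoxy-5-methylphenyl on an amide-type nitrogen in a ring. Among the measured compounds shown here, no measured pair shows this change alone. Starting from compound 1 at 300 nM as the nearest reference, no step beyond the scatter is expected in this assay, in either direction. The estimated step (a 1.2-fold lower number from compound 1 to compound 4 (0.08 log units; within the scatter)) stays within that scatter. For compound 4 the expected value is 250 nM (estimated range 90 nM to 700 nM).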

Compound 4, half-maximal inhibitory concentration: > 1000 nM
Compound 4: only a limit was reported (the forecaster's own chance of this, stated with the estimate: 7%); middle value at least 4.0-fold (0.60 log units) from the limit.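

In this assay, placing 4-(diethylamino)phenyl on the amide-type nitrogen in a ring gives an at least 3.3-fold higher number from compound 1 to compound 4 (0.52 log units; beyond the scatter). Among the compounds shown here, this is the first pair to isolate a change at this position, and it shows that the group held here can matter beyond the scatter. Compound 4 stands at > 1000 nM, which is a limit and not a number, so the full size of the step stays unknown: the limit of > 1000 nM in this assay, at which 2 of the 4 values shown sit.

The swap removes the methoxy and methyl groups and adds the diethylamino group at once, so these contributions cannot be separated. As far as these compounds go, how a dimethylamino group or an unsubstituted phenyl would behave here remains open.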